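The compounds below may be only part of what the source reports. "The series", "measured", "known", "first", "only" and "open" are said of these compounds alone.

Measured compounds:
compound 1, `COc1cc(OC)c2cc(-c3ccccc3)c(O)nc2c1`: 10000 nM
compound 2, `COc1ccc(-c2cc3c(OC)cc(OC)cc3n(C)c2=O)cc1`: 10000 nM

In a functional assay on MCF7 cells (Homo sapiens) for cytotoxicity, read by colorimetric assay and MTT assay (on this read-out lower numbers stand for stronger inhibition and higher numbers for weaker inhibition), compound 1 gives 10000 nM. In this assay compound 2 gives 10000 nM, level with compound 1 at the digits shown; its nearest neighbour on this read-out is compound 1, with no change within the scatter. Nothing separates the two on the numbers shown.

Compound 3, `COc1ccc(-c2cc3c(OC)cc(OC)cc3n(CC(=O)OCc3ccccc3)c2=O)cc1`, has not been measured in this assay. Relative to compound 2 the change is benzyloxycarbonyl in place of hydrogen on a saturated chain carbon bound to an aromatic nitrogen. Among the compounds with values here, no step between measured compounds is known that resembles this change, so there is nothing to anchor its size or direction. Both measured compounds sit at the same value, and the expectation is a step no larger than the scatter, in no particular direction.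

For compound 3 the expected step is no change at the digits printed from compound 2 to compound 3 (within the scatter). For compound 3 the estimate in this assay is 10000 nM, with a range from 4000 nM to 25000 nM.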

Compound 3, half-maximal inhibitory concentration: 10000 nM
Beside the measured number, compound 3's estimate shows no gap at the digits printed; measured number inside the range.
By their numbers in this assay, from the lowest: compounds 1, 2 and 3 (each within the scatter of the next).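

Within the data shown here, on the saturated chain carbon bound to an aromatic nitrogen, the first measured step in this assay reads no change at the digits printed from compound 2 to compound 3 (within the scatter) with benzyloxycarbonyl in place of hydrogen. Read one bond further out, the same difference is methyl to (benzyloxycarbonyl)methyl, so at this place a group of 10 heavy atoms with one six-membered aromatic ring leaves the read-out within the scatter. No independent measurement bears on why this value holds.

Still open, on these data alone, is whether another group at this place, such as a carboxylic acid, a primary amide or an aminoethyl chain, would separate from compound 2 in this assay at all. Among these compounds, with all three compounds level, no step yet shows a direction for any change at this place or on the shared core.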